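The source may hold more compounds than are shown below. What is called first, only, known or untested is meant among the compounds shown, and "the series" means these compounds.

Compound 1 `COc1ccc(OC)c(C(=O)/C=C/c2ccsc2)c1` gives 5300 nM
Compound 2 `COc1ccc(OC)c(C(=O)/C=C/c2ccc(C)o2)c1` gives 43000 nM

In a functional assay on HT-29 cells (Homo sapiens) for cytotoxicity, read by MTT assay (a higher number here means a weaker inhibitor, a lower number a stronger inhibitor), compound 2 has the higher of the two numbers, which makes it the weaker inhibitor of the pair. Compound 3 `COc1ccc(OC)c(C(=O)/C=C/c2sccc2C)c1` has not yet been measured. It differs from compound 2 by 3-methylthiophen-2-yl in place of 5-methylfuran-2-yl on a double-bonded chain carbon bound to a double-bonded chain carbon, with 3-methylthiophen-2-yl in place of 5-methylfuran-2-yl on a double-bonded chain carbon bound to a double-bonded chain carbon.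

Among the measured compounds shown here, only one measured step bears on this change: an 8.1-fold higher number from compound 1 to compound 2 (0.91 log units; beyond the scatter), where 5-methylfuran-2-yl took the place of thiophen-3-yl. Compound 3 returns to a thiophene ring, but 3-methylthiophen-2-yl is not the same group as thiophen-3-yl, so only part of that step is expected to reverse. The expected change is a 3.6-fold lower number from compound 2 to compound 3 (0.55 log units; beyond the scatter), towards a lower number. The estimate for compound 3 is 12000 nM (expected range 3500 nM to 35000 nM) in this assay, a number yet to be tested.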

Compound 3, half-maximal inhibitory concentration: 19400 nM
The estimate for compound 3 lay 1.6-fold (0.21 log units) below the measured number; the measured number falls inside the stated range.
By their numbers in this assay, from the lowest: compound 1; then compound 3; then compound 2.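

In this assay there is a 2.2-fold lower number from compound 2 to compound 3 (0.35 log units; beyond the scatter) when 3-methylthiophen-2-yl replaces 5-methylfuran-2-yl, so this thiophene group recovers part of the gap that separated the first two compounds. Yet there is also a 3.7-fold higher number from compound 1 to compound 3 (0.56 log units; beyond the scatter) with the same group in place of thiophen-3-yl, which shows that a thiophene ring at this place does not by itself restore the number of compound 1. Nothing measured here explains either step.

The two thiophene groups differ both in the methyl and in how the ring is attached, and these compounds cannot separate those two changes. Going by these compounds, whether a pyridine ring, a plain phenyl ring or a chain carrying an amine at this place would give a lower number also remains open.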